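Replacing the chloro group of compound 1 with hydrogen

The source may report more compounds than this note shows. Statements on the series, on what has been measured and on what is new or still open speak of the compounds shown alone.

- compound 1 `CC(C)CCn1cnc2c(Nc3ccc(Cl)cc3)nc(N[C@H]3CC[C@H](N)CC3)nc21` gives 1800 nM
- compound 2 `CCCCn1cnc2c(Nc3ccc(Cl)cc3)nc(N[C@H]3CC[C@H](N)CC3)nc21` gives 2700 nM

Compound 1 has one measured neighbour in a functional assay on K562 cells (Homo sapiens) for inhibition, read by fluorescence, with a stated time of 72 h (a lower number here means a stronger inhibitor of growth, a higher number a weaker inhibitor of growth), and the gap to it lies within the scatter (a 1.5-fold higher number from compound 1 to compound 2 (0.18 log units; within the scatter)). Compound 3 `CC(C)CCn1cnc2c(Nc3ccccc3)nc(N[C@H]3CC[C@H](N)CC3)nc21` has hydrogen in place of chloro on an aromatic carbon. That one measured step concerns the chain of compound 1, not this aromatic carbon, so no measurement sizes the change. A small move toward a higher number in this assay is expected, with nothing clearly beyond the scatter (a 1.7-fold higher number from compound 1 to compound 3 (0.22 log units; within the scatter)). For compound 3 the estimate is 3000 nM, with an expected range from 1200 nM to 8000 nM.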

Compound 3, concentration for 50% growth inhibition: 3500 nM
Compound 3: middle estimate off by 1.2-fold (0.07 log units), on the low side, and the stated range covers the measured number.
By their numbers in this assay, from the lowest: compounds 1, 2 and 3 (each within the scatter of the next).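

In this assay, the change from 4-chlorophenyl to phenyl gives a 1.9-fold higher number from compound 1 to compound 3 (0.29 log units; within the scatter) and so gives this aromatic carbon a measured step of its own. Within these two compounds, the chloro group on this carbon cannot be told apart from hydrogen. No available evidence bears on this result.
The compounds shown leave open whether a fluoro group, a methoxy group or an amine on this same carbon would give a step beyond the scatter.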